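Taking the nitro group off compound 3

This account rests on a few compounds, and the source may have more. Where it says the series, first, only, none or still open, it means among the compounds named here.

In a functional assay on L1210 cells (Mus musculus) for antiproliferative activity (a lower number here means a stronger inhibitor, a higher number a weaker inhibitor), compound 3 `COc1cc(C(=O)c2sc(-c3cccc([N+](=O)[O-])c3)cc2N)cc(OC)c1OC` gives 11 nM and is the strongest of the three measured inhibitors. Compound 1 `COc1cc(C(=O)c2sc(-c3ccc([N+](=O)[O-])cc3)cc2N)cc(OC)c1OC` gives 100 nM and compound 2 `COc1cc(C(=O)c2sc(-c3ccc(Cl)cc3)cc2N)cc(OC)c1OC` gives 93 nM on the same read-out. These two are not separated, as a 1.1-fold lower number from compound 1 to compound 2 (0.03 log units; within the scatter) shows.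

Compound 4 `COc1cc(C(=O)c2sc(-c3ccccc3)cc2N)cc(OC)c1OC` differs from compound 3 by hydrogen in place of nitro on an aromatic carbon and the change is hydrogen in place of nitro on an aromatic carbon. Among the compounds with values here, no measured compound carries a plain phenyl, so the evidence is indirect. The two steps that bear on it are a 9.1-fold lower number from compound 1 to compound 3 (0.96 log units; beyond the scatter) and an 8.5-fold lower number from compound 2 to compound 3 (0.93 log units; beyond the scatter) and both are modest. Among these three compounds, only compound 3 carries the 3-nitrophenyl group. Removing that group is therefore expected to give back much of this gap, though perhaps not all of it. The expected move is a 6.4-fold higher number from compound 3 to compound 4 (0.80 log units; beyond the scatter) in this assay toward a weaker inhibitor. For compound 4 the estimated value is 70 nM with an expected range from 20 nM to 250 nM on this read-out.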

Compound 4, half-maximal inhibitory concentration: 11 nM
Estimate against measurement, compound 4: 6.4-fold (0.80 log units) above, outside the stated range (below it).
By their numbers in this assay, from the lowest: compounds 3 and 4 (each within the scatter of the next); then compounds 2 and 1 (each within the scatter of the next).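

In this assay the nitro group of compound 3 proves dispensable, with no change at the digits printed from compound 3 to compound 4 (within the scatter) on going from 3-nitrophenyl to phenyl. The lead that compound 3 held over the two other compounds is therefore not tied to nitro, since the plain phenyl keeps it, with an 8.5-fold lower number from compound 2 to compound 4 (0.93 log units; beyond the scatter) and a 9.1-fold lower number from compound 1 to compound 4 (0.96 log units; beyond the scatter) as the printed steps; the weaker numbers go with the chloro of compound 2 and the differently placed nitro of compound 1, while the nitro of compound 3 goes against any reading that a substituent as such weakens inhibition. Nothing available gives a reason for this result.

The compounds shown leave open whether this place tolerates groups other than nitro, such as an amine or a carboxylic acid. They also leave open whether chloro would match hydrogen if it stood where compound 3 carries its nitro.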